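Methylating a Hydroxyl on a Shared Core, With One Compound Untested

A few compounds are considered here, and "the series" means these few. Any claim that something is new, unique, unknown or untested is made for them only; others in the source may bear on it.

Compound 1 `COC(=O)c1c(-c2ccc([N+](=O)[O-])cc2)oc2ccccc2c1=O`: in a functional assay on Malme-3M cells (Homo sapiens) for cytotoxicity, read by MTT assay, with a stated time of 6 days (on this read-out higher numbers stand for an effect only at larger amounts of compound and lower numbers for an effect already at smaller amounts), compound 1 gives > 25 ug/mL, which is a limit of the assay and not a number.
Compound 2 `O=C(O)c1c(-c2ccc([N+](=O)[O-])cc2)oc2ccccc2c1=O`: in this assay compound 2 gives > 25 ug/mL, again only a limit.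
Compound 3 `COc1cc(-c2cc(=O)c3cc(O)ccc3o2)cc(OC)c1OC`: in this assay compound 3 gives > 25 ug/mL, also a limit.

Compound 2 and compound 1 differ in one place: methyl in place of hydrogen on an oxygen next to a carbonyl group. The size of that step, a step that the two limits leave unreadable from compound 2 to compound 1, cannot be read, because the limit of > 25 ug/mL in this assay, at which 3 of the 3 values shown sit, leaves both ends open. The difference between the core of compound 2 and the core of compound 3 is not broken down here.

Compound 4 `COc1ccc2oc(-c3cc(OC)c(OC)c(OC)c3)cc(=O)c2c1` has not yet been measured. It differs from compound 3 by methyl in place of hydrogen on an oxygen on an aromatic ring. For the measured compounds named here, this is the same kind of change as the one from compound 2 to compound 1, but the place differs: there the oxygen sits next to a carbonyl group with a carbonyl carbon as its other neighbour, here it sits on an aromatic ring with an aromatic carbon as its other neighbour.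

For compound 4 the step that the limit leaves unreadable from compound 3 to compound 4 is expected to be small, because the limit of > 25 ug/mL in this assay, at which 3 of the 3 values shown sit, shows every measured compound, compound 3 among them, resting at the same limit. Compound 4 is therefore estimated at 35 ug/mL, somewhere between 10 ug/mL and 120 ug/mL.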

Compound 4, concentration for half-maximal effect: > 25 ug/mL
Compound 4: no number, only a limit (the forecaster's own chance of this, stated with the estimate: 80%); the middle value lies beyond the limit too.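

The size of the step between compound 3 and compound 4, from hydroxy to methoxy, cannot be read, because neither compound gives a number: the limit of > 25 ug/mL in this assay, at which 4 of the 4 values shown sit.

The compounds shown leave open whether placing methyl on either oxygen changes the effect at all, and how the four compounds rank against each other in this assay.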